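Cyclopropyl sulfonamide replaces the carbamate-bearing chain

A few compounds are considered here, and "the series" means these few. Any claim that something is new, unique, unknown or untested is made for them only; others in the source may bear on it.

Of the compounds shown here, two have been measured in an ADME assay on microsomes from liver (Rattus norvegicus) for metabolic stability, with a stated time of 10 min; on this read-out higher numbers stand for a more stable compound and lower numbers for a less stable compound. Compound 1 `CC(C)OC(=O)NCCS(=O)(=O)NC(=O)c1ccc(Nc2nc(NC3(c4ccc(Cl)cc4)CC3)nc(OCC(F)(F)F)n2)cc1` gives 73% in this assay, and compound 2 `COC(=O)NCCS(=O)(=O)NC(=O)c1ccc(Nc2nc(NC3(c4ccc(Cl)cc4)CC3)nc(OCC(F)(F)F)n2)cc1` gives 100%. For the measured compounds named here, compound 2 therefore stands highest of the two numbers, with compound 1 as its only neighbour; the step of a number 27 percentage points higher from compound 1 to compound 2 (beyond the scatter) is beyond the scatter and reflects a methyl in place of an isopropyl on an oxygen next to a carbonyl group.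

Compound 3 `O=C(NS(=O)(=O)C1CC1)c1ccc(Nc2nc(NC3(c4ccc(Cl)cc4)CC3)nc(OCC(F)(F)F)n2)cc1` is not yet measured. It differs from compound 2 as follows: cyclopropyl in place of 2-((methoxycarbonyl)amino)ethyl on a sulfonyl sulfur. Going by the values given here, the only measured step, from compound 1 to compound 2, touched the methoxycarbonyl end of that same chain, so it bears on the change only loosely, and no step in which the whole chain is removed has been measured. Since compound 2 already sits at the top of the range, any movement in this assay can only be downward or none beyond the scatter. Compound 3 is expected to remain stable, with an estimated step of a number 12 percentage points lower from compound 2 to compound 3 (beyond the scatter), giving an estimate of 88% for compound 3, with a range from 60% to 100%.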

Compound 3, percent of the compound remaining: 85%
Beside the measured number, compound 3's estimate is 3 percentage points above it; the measured number falls inside the stated range.
By their numbers in this assay, from the lowest: compound 1; then compound 3; then compound 2.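

The earlier step changed only the end of the chain, whereas this result shows that the whole 2-((methoxycarbonyl)amino)ethyl group on the sulfonyl sulfur can be replaced by the much smaller cyclopropyl while stability in this assay stays fairly high, although the read-out moves a number 15 percentage points lower from compound 2 to compound 3 (beyond the scatter) in this comparison. Replacing the chain that ends in isopropyl gives the opposite direction, a number 12 percentage points higher from compound 1 to compound 3 (beyond the scatter) here, so the same cyclopropyl group gains or loses depending on which chain it replaces, and compound 3 falls between the two chain-bearing compounds. The material shown offers no measured explanation for this order.

As far as these compounds go, what a plain ethyl group, a longer alkyl chain, or a chain ending in an amine or a carboxylic acid would do on the sulfonyl sulfur remains open, as does whether the three-membered ring matters or only the removal of the longer chain. From the compounds shown here alone, it is also open whether this order of the three compounds would hold in any read-out other than this assay and at other incubation times.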